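Nitro in place of methoxy: compound 3 to compound 4

The compounds below may be only part of what the source reports. "The series", "measured", "known", "first", "only" and "open" are said of these compounds alone.

- compound 1 `COc1ccc2nc(-c3ccc(N/C=C\C(=O)c4ccc(OC)c(O)c4)c(C)c3)sc2c1` gives 12000 nM
- compound 2 `COc1ccc2nc(-c3ccc(N/C=C\C(=O)c4cc(OC)c(OC)c(OC)c4)c(C)c3)sc2c1` gives 16100 nM
- compound 3 `COc1ccc2nc(-c3ccc(N/C=C\C(=O)c4cc(OC)c(OC)c(OC)c4)cc3)sc2c1` gives 14100 nM

In a functional assay on HeLa cells (Homo sapiens) for antiproliferative activity, read by sulforhodamine B assay, with a stated time of 48 h (a higher number here means a weaker inhibitor, a lower number a stronger inhibitor), compound 3 stands at 14100 nM and lies within the scatter of both compound 2 and compound 1, so it holds no separate rank. Compound 4 `COc1ccc2nc(-c3ccc(N/C=C\C(=O)c4cc(OC)c(OC)c([N+](=O)[O-])c4)cc3)sc2c1` differs from compound 3 by nitro in place of methoxy on an aromatic carbon. For the measured compounds named here, the only measured step (a 1.1-fold lower number from compound 2 to compound 3 (0.06 log units; within the scatter)) swaps hydrogen for methyl at another place and offers indirect guidance at best. Going by the values given here, no measured step covers this exchange. No shift beyond the scatter is expected in this assay and the estimated step (a 1.1-fold lower number from compound 3 to compound 4 (0.04 log units; within the scatter)) carries no firm direction. Compound 4 is estimated at 13000 nM with an expected range from 5500 nM to 30000 nM and awaits measurement.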

Compound 4, half-maximal inhibitory concentration: 16100 nM
Beside the measured number, compound 4's estimate is 1.2-fold (0.09 log units) below it; the measured number falls inside the stated range.
By their numbers in this assay, from the lowest: compounds 1, 3, 2 and 4 (each within the scatter of the next).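

Nitro in place of methoxy on this aromatic carbon, ortho to a methoxy group and meta to a large group, gives a 1.1-fold higher number from compound 3 to compound 4 (0.06 log units; within the scatter) in this assay. For the compounds shown here, the earlier step touched only a methyl elsewhere, so this is the first sign that the methoxy group here can be exchanged without a shift beyond the scatter. No evidence is available to explain this result.

On these data alone, whether an amine or a carboxylic acid on this carbon would give a shift beyond the scatter remains open. Also open, as far as these compounds go, is whether a single exchange at either of the other two methoxy groups would do so.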